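Replacing 4-hydroxy-2-methylphenyl with 4-ethylphenyl

This account rests on a few compounds, and the source may have more. Where it says the series, first, only, none or still open, it means among the compounds named here.

In a functional assay on MDA-MB-231 cells (Homo sapiens) for inhibition, read by sulforhodamine B assay, with a stated time of 48 h (on this read-out lower numbers stand for stronger inhibition of growth and higher numbers for weaker inhibition of growth), compound 1 (`Cc1ccc(C2=NN(c3ccc(S(C)(=O)=O)cc3)C(=O)CC2)cc1`) gives 830 nM and compound 2 (`Cc1cc(O)ccc1C1=NN(c2ccc(S(C)(=O)=O)cc2)C(=O)CC1`) gives 17100 nM, so compound 2 holds the higher number of the two and is the weaker inhibitor of growth. Compound 3 (`CCc1ccc(C2=NN(c3ccc(S(C)(=O)=O)cc3)C(=O)CC2)cc1`) differs from compound 2 by 4-ethylphenyl in place of 4-hydroxy-2-methylphenyl on a carbon with a double bond to nitrogen, with 4-ethylphenyl in place of 4-hydroxy-2-methylphenyl on a carbon with a double bond to nitrogen. Going by the values given here, one measured step bears on this change: a 21-fold higher number from compound 1 to compound 2 (1.31 log units; beyond the scatter), large and beyond the scatter, with 4-hydroxy-2-methylphenyl in place of 4-methylphenyl. Compound 3 gives up that same group, so a large step of similar size towards lower numbers is expected in this assay. Among the compounds with values here, no measured compound carries 4-ethylphenyl, which widens the uncertainty. The expected step is a 16-fold lower number from compound 2 to compound 3 (1.19 log units; beyond the scatter). For compound 3 the estimate is 1100 nM, with a range from 350 nM to 3500 nM.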

Compound 3, concentration for 50% growth inhibition: 3460 nM
Compound 3: middle estimate off by 3.1-fold (0.50 log units), on the low side; low and high end bracket the measured number.
By their numbers in this assay, from the lowest: compound 1; then compound 3; then compound 2.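

In this assay, the change to 4-ethylphenyl brings a 4.9-fold lower number from compound 2 to compound 3 (0.69 log units; beyond the scatter) and so recovers part of what 4-hydroxy-2-methylphenyl lost at this position. The alkyl group itself also matters here: there is a 4.2-fold higher number from compound 1 to compound 3 (0.62 log units; beyond the scatter) when the 4-methylphenyl group gains one methyl, which shows that even a change confined to this chain moves the number beyond the scatter. No evidence is available that explains either step.

The compounds shown carry the hydroxyl and the extra ring methyl together in 4-hydroxy-2-methylphenyl, so 4-hydroxyphenyl and 2-methylphenyl would be needed to separate their contributions. Going by these compounds, whether the number keeps rising with a longer chain such as 4-propylphenyl, or how a 4-methoxyphenyl or 4-aminophenyl group would behave at this position, also remains open.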